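The compounds below may be only part of what the source reports. "The series", "measured", "known", "first", "only" and "open" are said of these compounds alone.

Going by the values given here, in an ADME assay on MT4 cells (Homo sapiens) for cytotoxicity, read by MTT assay (on this read-out lower numbers stand for higher toxicity in this test and higher numbers for lower toxicity in this test), compound 1 `O=C1c2ccccc2C(=O)N1CCOC(=S)N(C(=O)c1cccc([N+](=O)[O-])c1)c1ccc(Cl)cc1` gives 18000 nM, the only actual number in this small set. Compound 2 `Cc1ccc(C(=O)N(C(=S)OCCN2C(=O)c3ccccc3C2=O)c2ccc(Cl)cc2)cc1` gives > 100000 nM, which is a limit. Compound 3 `O=C1c2ccccc2C(=O)N1CCOC(=S)N(C(=O)c1ccc([N+](=O)[O-])cc1)c1ccc(Cl)cc1` gives > 100000 nM, also a limit. Two measured steps replace the 3-nitrophenyl on a carbonyl carbon: an at least 5.5-fold higher number from compound 1 to compound 2 (0.74 log units; beyond the scatter) and an at least 5.5-fold higher number from compound 1 to compound 3 (0.74 log units; beyond the scatter). Compound 4 `Cc1ccc(N(C(=O)c2cccc([N+](=O)[O-])c2)C(=S)OCCN2C(=O)c3ccccc3C2=O)cc1` keeps that 3-nitrophenyl and instead carries methyl in place of chloro on an aromatic carbon, (methyl in place of chloro on an aromatic carbon). Among the compounds with values here, no measured step touches this place, so neither size carries over, and no step beyond the scatter is expected in this assay. The estimate therefore means a 1.4-fold higher number from compound 1 to compound 4 (0.14 log units; within the scatter). For compound 4 the expected value is 25000 nM, with an estimated range of 7000 nM to 80000 nM.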

Compound 4, half-maximal cytotoxic concentration: 100000 nM
Compound 4: the middle estimate sits 4.0-fold (0.60 log units) below what was measured; the whole stated range lies below it.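

Going by these compounds alone, the change from 4-chlorophenyl to 4-methylphenyl, a place the earlier steps left untouched, gives in this assay a 5.6-fold higher number from compound 1 to compound 4 (0.74 log units; beyond the scatter). All three single changes shown from compound 1 give higher numbers, so its lower number is not tied to the 3-nitrophenyl alone. The number of compound 4 matches the figure of the limit reached elsewhere in this set: the limit of > 100000 nM in this assay, at which 2 of the 4 values shown sit.

As far as these compounds go, whether fluoro, bromo or methoxy at this place would act like methyl stays open. So does how far above that figure the methyl change might read.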